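Shortening the Side Chain of Compound 2: What to Expect

This account rests on a few compounds, and the source may have more. Where it says the series, first, only, none or still open, it means among the compounds named here.

Two compounds have been examined in a functional assay on HEL cells (Homo sapiens), read by microscopy; a lower number here means that less compound is tolerated, a higher number that more compound is tolerated. Compound 1, with the structure `CCCCCCCc1cc2cn(COCCO)c(O)nc-2n1`, carries a heptyl chain on its core. Compound 2, with the structure `CCCCCCCCCCCc1cc2cn(COCCO)c(=O)nc2o1`, carries an undecyl chain on a closely related core. In this assay, among the compounds with values here, compound 2 gives 80000 nM, and this is the only actual number in the set. Compound 1 reaches only a limit of the assay, >= 400000 nM, so the set holds one number and one limit (the limit of >= 400000 nM in this assay, at which 1 of the 2 values shown sits).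

Compound 3, with the structure `CCCCCCc1cc2cn(COCCO)c(=O)nc2o1`, is the next compound to be tested. It differs from compound 2 in one place: hydrogen in place of pentyl on a saturated chain carbon, six bonds along the chain from an aromatic carbon. Within the data shown here, no pair of measured compounds differs in just one place, so no measured step sets a scale for this change.

The expectation is a step upward in this assay, meaning that more of compound 3 is tolerated than of compound 2, and the step from compound 2 to compound 3 is estimated as a 3.1-fold higher number from compound 2 to compound 3 (0.49 log units; beyond the scatter). Compound 3 is therefore expected to give about 250000 nM, within a range from 60000 nM to 1000000 nM.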

Compound 3, minimum cytotoxic concentration: >= 400000 nM
Compound 3: a limit, no number; the forecaster's own chance of this, stated with the estimate: 45%; at least 1.6-fold (0.20 log units) between middle value and limit.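

Within the data shown here, replacing pentyl with hydrogen on a saturated chain carbon, six bonds along the chain from an aromatic carbon, gives an at least 5.0-fold higher number from compound 2 to compound 3 (0.69 log units; beyond the scatter) in this assay, and this is the first change in a single place to have a measured size in this set. Compound 3 gives >= 400000 nM, which is a limit of the assay and not a number, so the step has a lower bound but no known upper end. On this core, then, cutting the undecyl chain down to hexyl moves the result beyond the usual scatter and takes it to a limit shared with another compound of the set: the limit of >= 400000 nM in this assay, at which 2 of the 3 values shown sit.

The compounds shown leave open how the read-out changes between these two chain lengths, and an octyl or a nonyl chain on the same core could show whether the rise comes gradually or all at once. Also open, from the compounds shown here alone, are how far past the limit compound 3 really lies and what a chain carrying a carboxylic acid would give.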